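The compounds below may be only part of what the source reports. "The series", "measured", "known", "first", "only" and "open" are said of these compounds alone.

Measured in a functional assay on HepG2 cells (Homo sapiens) for cytotoxicity, read by MTT assay, with a stated time of 48 h; on this read-out higher numbers stand for weaker inhibition and lower numbers for stronger inhibition:
compound 1 `COc1cccc(-n2cc(CO/N=C3\CC[C@]4(C)[C@@H](CC/C=C(\C)CC/C=C(\C)CCC=C(C)C)[C@](C)(O)CC[C@H]4C3(C)C)nn2)c1`, 51300 nM
compound 2 `CC(C)=CCC/C(C)=C/CC/C(C)=C/CC[C@@H]1[C@@]2(C)CC/C(=N\OCc3cn(-c4ccc(F)cc4)nn3)C(C)(C)[C@@H]2CC[C@@]1(C)O`, 63100 nM
compound 3 `CC(C)=CCC/C(C)=C/CC/C(C)=C/CC[C@@H]1[C@@]2(C)CC/C(=N\OCc3cn(-c4ccccc4C#N)nn3)C(C)(C)[C@@H]2CC[C@@]1(C)O`, 21900 nM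

Compound 2 stands at the upper end of these numbers and shares that end with compound 1: a 1.2-fold higher number from compound 1 to compound 2 (0.09 log units; within the scatter). Within the data shown here, the one value set apart is the lower one, with a 2.9-fold lower number from compound 2 to compound 3 (0.46 log units; beyond the scatter) and a 2.3-fold lower number from compound 1 to compound 3 (0.37 log units; beyond the scatter), both modest.

Compound 4 `CC(C)=CCC/C(C)=C/CC/C(C)=C/CC[C@@H]1[C@@]2(C)CC/C(=N\OCc3cn(-c4cccc(C(F)(F)F)c4)nn3)C(C)(C)[C@@H]2CC[C@@]1(C)O` has not yet been measured in this assay. The change is 3-(trifluoromethyl)phenyl in place of 4-fluorophenyl on an aromatic nitrogen of a five-membered aromatic ring with 3 nitrogen.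

All three measured steps are exchanges of the group on this same nitrogen, so they set the scale, although none involves trifluoromethyl. Their sizes run from within the scatter to modest, and only compound 3 departs from the other two. A small step, or none beyond the scatter, is therefore expected. With compound 2 at 63100 nM at the upper end, any step is expected toward a lower number. The expected change is a 1.4-fold lower number from compound 2 to compound 4 (0.15 log units; within the scatter). For compound 4 the estimated value is 45000 nM, with an expected range from 20000 nM to 90000 nM.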

Compound 4, half-maximal inhibitory concentration: 22700 nM
The estimate for compound 4 lay 2.0-fold (0.30 log units) above the measured number; the measured number falls inside the stated range.
By their numbers in this assay, from the lowest: compounds 3 and 4 (each within the scatter of the next); then compounds 1 and 2 (each within the scatter of the next).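

In this assay the group on the aromatic nitrogen of the five-membered ring shifts the number through a second, independent exchange: 3-(trifluoromethyl)phenyl in place of 4-fluorophenyl gives a 2.8-fold lower number from compound 2 to compound 4 (0.44 log units; beyond the scatter) and trifluoromethyl in place of methoxy on an aromatic carbon gives a 2.3-fold lower number from compound 1 to compound 4 (0.35 log units; beyond the scatter), so compound 3 no longer stands alone at the lower end. The comparison with 2-cyanophenyl gives a 1.0-fold higher number from compound 3 to compound 4 (0.02 log units; within the scatter), which places two differently substituted groups at one level, while 3-methoxyphenyl and 4-fluorophenyl share the upper level, and all four compounds fit this split into two pairs, with every step between the pairs modest. Nothing at hand accounts for this split.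

The compounds shown leave open whether an amine or a carboxylic acid on the six-membered aromatic ring would follow the same split or move the number further than these modest steps. They also leave open what a plain alkyl chain would do on the aromatic nitrogen in place of the six-membered aromatic ring, since every group compared here keeps that ring.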